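Working notes: one stereocentre changed in compound 1

The source may report more compounds than this note shows. Statements on the series, on what has been measured and on what is new or still open speak of the compounds shown alone.

Measured in a functional assay on A549 cells (Homo sapiens) for inhibition, read by colorimetric assay and MTT assay, with a stated time of 72 h; a lower number here means a stronger inhibitor, a higher number a weaker inhibitor (values in brackets):
- compound 1 `C/C1=C\CC[C@@]2(C)O[C@@H]2[C@H]2OC(=O)[C@@H](CN3CCCCC3)[C@@H]2C[C@H]1O` (18000 nM)
- compound 2 `C/C1=C\CC[C@@]2(C)O[C@@H]2[C@H]2OC(=O)[C@@H](CN3CCN(C)CC3)[C@@H]2C[C@H]1O` (30000 nM)
- compound 3 `C/C1=C\CC[C@@]2(C)O[C@@H]2[C@H]2OC(=O)[C@@H](CN(C)CCN(C)C)[C@@H]2C[C@H]1O` (8000 nM)

Compound 1 sits within the scatter of its nearest neighbour (a 1.7-fold higher number from compound 1 to compound 2 (0.22 log units; within the scatter)) and clearly apart from the remaining compound (a 2.3-fold lower number from compound 1 to compound 3 (0.35 log units; beyond the scatter)). It therefore belongs with compound 2 at the high end of these numbers, which is the weaker end.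

Compound 4 `C/C1=C\CC[C@@]2(C)O[C@@H]2[C@H]2OC(=O)[C@@H](CN3CCCCC3)[C@@H]2C[C@@H]1O` keeps the atoms and bonds of compound 1 and changes only in configuration (the two compounds have the same atoms and bonds and differ only in configuration as drawn: 1 of 7 stereo elements differ; a stereocentre at a saturated ring carbon is drawn R in compound 1 and S in compound 4): a stereocentre at a saturated ring carbon is drawn R in compound 1 and S in compound 4.

Going by the values given here, no measured step tests a change of configuration. All three measured steps exchange the amine group, and the largest of them is still modest (a 3.8-fold lower number from compound 2 to compound 3 (0.57 log units; beyond the scatter)). They show how far numbers have moved in this series in this assay, but they give no direction for the present change. Among the compounds with values here, with no precedent either way, no step beyond the scatter is expected, though the margin on both sides stays wide.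

The expected step, an estimate only, is small (a 1.1-fold higher number from compound 1 to compound 4 (0.05 log units; within the scatter)).

Compound 4 is estimated at 20000 nM (expected range 8000 nM to 50000 nM).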

Compound 4, half-maximal inhibitory concentration: 6000 nM
Beside the measured number, compound 4's estimate is 3.3-fold (0.52 log units) above it; the whole stated range lies above it.
By their numbers in this assay, from the lowest: compounds 4 and 3 (each within the scatter of the next); then compounds 1 and 2 (each within the scatter of the next).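

The configuration at this saturated ring carbon carries weight in this assay: going from the R to the S drawing, with piperidin-1-yl kept in place, gives a 3.0-fold lower number from compound 1 to compound 4 (0.48 log units; beyond the scatter). Going by these compounds alone, until now, the only changes that moved the numbers beyond the scatter were exchanges of the amine group, the largest being a 3.8-fold lower number from compound 2 to compound 3 (0.57 log units; beyond the scatter), and the present step shows that a change of configuration alone can also produce a modest step. The shift can be assigned to this single stereocentre, because no other structural difference exists between the pair: the fact that compounds 1 and 4 differ only in the configuration as drawn

The compounds shown leave open whether the S configuration gives a step of the same direction when 4-methylpiperazin-1-yl or (2-(dimethylamino)ethyl)(methyl)amino takes the place of piperidin-1-yl. They also leave open how the S configuration behaves with another amine, such as morpholin-4-yl, and whether the step from compound 1 to compound 4 extends beyond A549 cells to any other cell line.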